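A few compounds are considered here, and "the series" means these few. Any claim that something is new, unique, unknown or untested is made for them only; others in the source may bear on it.

Working notes on the series. In a functional assay on A549 cells (Homo sapiens) for antiproliferative activity, read by MTT assay, with a stated time of 72 h (on this read-out lower numbers stand for stronger inhibition and higher numbers for weaker inhibition), compound 1 `CNc1nc(-c2cc(OC)c(OC)c(OC)c2)c(-c2ccc(C)cc2)s1` gives 125 nM, while compound 2 `COc1cc(-c2nc(N(C)C)sc2-c2ccc(C)cc2)cc(OC)c1OC` gives 3960 nM, the higher of the two numbers and so the weaker inhibition. Compound 3 `COc1cc(-c2nc(C)sc2-c2ccc(C)cc2)cc(OC)c1OC` is the next to consider. Its change from compound 2 is methyl in place of dimethylamino on an aromatic carbon of the five-membered aromatic ring with 1 nitrogen and 1 sulfur.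

Within the data shown here, only one measured step bears on this: a 32-fold higher number from compound 1 to compound 2 (1.50 log units; beyond the scatter), a large step that came from methyl in place of hydrogen on a nitrogen on an aromatic ring. Among the measured compounds shown here, that step alters the same group that compound 3 gives up, but no measured compound has a methyl directly on this ring carbon, so the guidance is loose. A lower number than that of compound 2 seems likelier than a higher one, with a moderate step smaller than the measured one. The expected step is a 5.0-fold lower number from compound 2 to compound 3 (0.69 log units; beyond the scatter). In this assay the estimate for compound 3 is 800 nM, with an expected range from 120 nM to 5000 nM.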

Compound 3, half-maximal inhibitory concentration: 1950 nM
Beside the measured number, compound 3's estimate is 2.4-fold (0.39 log units) below it; the measured number falls inside the stated range.
By their numbers in this assay, from the lowest: compound 1; then compound 3; then compound 2.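

The position tolerates a swap of dimethylamino for methyl with only a limited shift in this assay: a 2.0-fold lower number from compound 2 to compound 3 (0.31 log units; beyond the scatter), a modest step that is still beyond the scatter. The nitrogen is therefore not required for a measurable read-out at this ring carbon, yet replacing methylamino with methyl gives a 16-fold higher number from compound 1 to compound 3 (1.19 log units; beyond the scatter), a large step, so compound 1 keeps the lowest number of the three, and both of its neighbours sit well above it. Among these compounds, methylamino is the only group on this carbon that gives a low number, and no measurement at hand explains why it stands apart from dimethylamino and methyl.

The compounds shown leave open whether the effect follows from the nitrogen's single methyl or from the amino nitrogen as such, which a plain amino group or an ethylamino group on the same carbon would help to separate. They also leave open how a hydroxyl or methoxy group would read here, and whether the order of the three holds in any cell line other than this one.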